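Swapping the aryl group on the carbonyl of a thiazole imide

The source may hold more compounds than are shown below. What is called first, only, known or untested is meant among the compounds shown, and "the series" means these compounds.

Measured so far:
compound 1, `Cc1ccccc1C(=O)/N=c1\scc(C)n1-c1cc(Cl)c(Cl)cc1Cl`: 150 nM
compound 2, `Cc1cs/c(=N\C(=O)c2ccco2)n1-c1cc(Cl)c(Cl)cc1Cl`: 100 nM

In an assay on isolated protein for inhibition of Alpha glucosidase (Homo sapiens), with stated times of 5 min and 30 min (on this read-out lower numbers stand for stronger inhibition and higher numbers for weaker inhibition), compound 2 shows the lowest of the two numbers, with compound 1 the nearest, separated by a 1.5-fold lower number from compound 1 to compound 2 (0.18 log units; within the scatter). Compound 3, `Cc1cs/c(=N\C(=O)c2ccccc2Cl)n1-c1cc(Cl)c(Cl)cc1Cl`, differs from compound 2 by 2-chlorophenyl in place of furan-2-yl on a carbonyl carbon. For the measured compounds named here, the one comparable step, a change of the aryl group on the same carbonyl carbon, is a 1.5-fold lower number from compound 1 to compound 2 (0.18 log units; within the scatter), so no movement beyond the scatter is expected from compound 2 to compound 3 in this assay, roughly a 1.5-fold higher number from compound 2 to compound 3 (0.18 log units; within the scatter). Compound 3 is therefore expected to give about 150 nM, between 70 nM and 320 nM.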

Compound 3, half-maximal inhibitory concentration: 100 nM
For compound 3 the middle estimate is 1.5-fold (0.18 log units) above the measured one; low and high end bracket the measured number.
By their numbers in this assay, from the lowest: compounds 2, 3 and 1 (each within the scatter of the next).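

In this assay, the step of no change at the digits printed from compound 2 to compound 3 (within the scatter) shows that this carbonyl carbon can carry 2-chlorophenyl as well as furan-2-yl without a reading beyond the scatter, even though a six-membered carbon ring replaces a five-membered ring with a hetero atom. With chloro in place of methyl on an aromatic carbon, the step of a 1.5-fold lower number from compound 1 to compound 3 (0.18 log units; within the scatter) also stays small. Nothing available here bears on these results. On these data alone, all three compounds carry an aromatic ring on this carbonyl, so an amine or a longer alkyl chain there remains open, as does a carboxylic acid on the ring.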